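A few compounds are considered here, and "the series" means these few. Any claim that something is new, unique, unknown or untested is made for them only; others in the source may bear on it.

Measured so far:
Compound 1 `Cc1cccc(C(=O)/C=C/c2ccc([N+](=O)[O-])o2)c1` — in an ADME assay on Vero cells (Chlorocebus sabaeus) for cytotoxicity, read by resazurin assay, with a stated time of 72 h (a higher number here means that more compound is tolerated, a lower number that less compound is tolerated), compound 1 gives 55100 nM.
Compound 2 `COc1ccc(/C=C/C(=O)c2cccc(I)c2)cc1` — in this assay compound 2 gives > 100000 nM, which is a limit of the assay and not a number.

Among the compounds with values here, compound 1 therefore stands as the only numbered value in this assay; the other entry sits at the limit of > 100000 nM in this assay, at which 1 of the 2 values shown sits. Compound 3 `O=C(/C=C/c1ccc([N+](=O)[O-])o1)c1cccc(Br)c1` keeps the core of compound 1 and differs from it only by bromo in place of methyl on an aromatic carbon. Within the data shown here, no step between two measured compounds is available here, so the data give no direct guide to how such an exchange shifts the half-maximal cytotoxic concentration. The author expects a step from compound 1 to compound 3 of a 1.1-fold lower number from compound 1 to compound 3 (0.04 log units; within the scatter), that is, none beyond the usual scatter, in either direction. Compound 3 is accordingly estimated at 50000 nM in this assay, with a range from 20000 nM to 100000 nM, and the measurement will show whether that holds.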

Compound 3, half-maximal cytotoxic concentration: 68800 nM
Compound 3: middle estimate off by 1.4-fold (0.14 log units), on the low side, and the stated range covers the measured number.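

In this assay, within the data shown here, bromo in place of methyl on an aromatic carbon, meta to a large group, gives a 1.2-fold higher number from compound 1 to compound 3 (0.10 log units; within the scatter), the first step that can be read. On this single pair, compound 1 and compound 3 cannot be told apart in their half-maximal cytotoxic concentration, so this place on the six-membered ring holds either methyl or bromo on the shared core without a difference beyond the scatter. Compound 2 remains a limit of the assay and not a number, and it offers no step to set beside this one: the limit of > 100000 nM in this assay, at which 1 of the 3 values shown sits.

What the compounds shown leave open is whether this place would read the same with an amine, a carboxylic acid or a longer chain. They also leave open whether bromo in place of methyl would give a similar step on a different core.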